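Adding a Carboxyethyl Chain to a Second Core

The source may report more compounds than this note shows. Statements on the series, on what has been measured and on what is new or still open speak of the compounds shown alone.

Compound 1 `Cc1ccc(Cn2c(/C=C3\SC(=S)NC3=O)nc3ccccc32)cc1` and compound 2 `Cc1ccc(Cn2c(/C=C3\SC(=S)N(CCC(=O)O)C3=O)nc3ccccc32)cc1` share one core; what separates them is 2-carboxyethyl in place of hydrogen on an amide-type nitrogen in a ring. In a functional assay on HL-60 cells (Homo sapiens) for cytotoxicity, read by MTT assay, with a stated time of 48 h (a higher number here means a weaker inhibitor, a lower number a stronger inhibitor), compound 1 gives 2660 nM, while compound 2 gives 4140 nM, which is a 1.6-fold higher number from compound 1 to compound 2 (0.19 log units; within the scatter). Compound 3 `O=C1NC(=S)S/C1=C\c1nc2ccccc2n1Cc1ccccc1F` has a core that differs from that of compound 1 only by 2-fluorophenyl in place of 4-methylphenyl on a saturated chain carbon bound to an aromatic nitrogen; in this assay compound 3 gives 8420 nM, a step of a 3.2-fold higher number from compound 1 to compound 3 (0.50 log units; beyond the scatter). Compound 4 `O=C(O)CCN1C(=O)/C(=C/c2nc3ccccc3n2Cc2ccccc2F)SC1=S` is compound 3 carrying the same change that turned compound 1 into compound 2, namely (2-carboxyethyl in place of hydrogen on an amide-type nitrogen in a ring), at exactly the same place. The step from compound 3 to compound 4 is expected to be a 1.5-fold higher number from compound 3 to compound 4 (0.17 log units; within the scatter) because a 1.6-fold higher number from compound 1 to compound 2 (0.19 log units; within the scatter). Compound 4 is therefore estimated to give about 12500 nM in this assay, expected between 6000 nM and 26000 nM.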

Compound 4, half-maximal inhibitory concentration: 5720 nM
Estimate against measurement, compound 4: 2.2-fold (0.34 log units) above; the measured number lies below the stated range.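

Adding the 2-carboxyethyl group gives a 1.5-fold lower number from compound 3 to compound 4 (0.17 log units; within the scatter) in this assay, and this step does not differ from the earlier one beyond what repeated measurements produce: the same change on two cores in this assay, a 1.6-fold higher number (0.19 log units; within the scatter) from compound 1 to compound 2 and a 1.5-fold lower number (0.17 log units; within the scatter) from compound 3 to compound 4, 2.3-fold (0.36 log units) apart, within the scatter of two such steps

The swap to 2-fluorophenyl gives a 1.4-fold higher number from compound 2 to compound 4 (0.14 log units; within the scatter), and this step is also consistent with its earlier counterpart: the same change on two cores in this assay, a 3.2-fold higher number (0.50 log units; beyond the scatter) from compound 1 to compound 3 and a 1.4-fold higher number (0.14 log units; within the scatter) from compound 2 to compound 4, 2.3-fold (0.36 log units) apart, within the scatter of two such steps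

Neither change is shown to depend on the core, but two cores cannot prove that either change behaves identically, and both 2-carboxyethyl steps lie within the scatter, so no real effect of that group is shown.

Going by these compounds, it remains open whether a longer chain on the same nitrogen, or an amine in place of the carboxylic acid, would give a step beyond the scatter. A third core would also be needed to test how far either change carries.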